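The source may report more compounds than this note shows. Statements on the series, on what has been measured and on what is new or still open speak of the compounds shown alone.

Series values in a functional assay on MCF7 cells (Homo sapiens) for inhibition, read by MTT assay, with a stated time of 72 h (a lower number here means a stronger inhibitor, a higher number a weaker inhibitor), are as follows.

- Compound 1 `CC[C@@H](C)[C@H](NC(=O)c1cc(Cl)ccc1OCCN)C(=O)Nc1ccc([N+](=O)[O-])cc1Cl` gives > 10000 nM as a limit of the assay
- Compound 2 `CC(C)[C@H](NC(=O)c1cc(Cl)ccc1OCCN)C(=O)Nc1ccc2c(c1)S(=O)(=O)C=C2` gives 4350 nM
- Compound 3 `CC(C)(C)OC(=O)NCCOc1ccc(Cl)cc1C(=O)NCC(=O)Nc1ccc2c(c1)S(=O)(=O)C=C2` gives 1430 nM

Compound 3 holds the lower of the two numeric values, and its gap to compound 2 lies beyond the usual scatter. The value for compound 1 is a limit and not a number.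

Compound 4 `NCCOc1ccc(Cl)cc1C(=O)NCC(=O)Nc1ccc2c(c1)S(=O)(=O)C=C2` comes from compound 3 by a single change, hydrogen in place of tert-butoxycarbonyl on an amine nitrogen which leaves a 2-aminoethyl group. Going by the values given here, no measured pair isolates this change, so the expectation rests on indirect evidence. Compound 2 also carries 2-aminoethyl and stands at 4350 nM in this assay on a higher number than compound 3, so a modest rise somewhat beyond the scatter is expected. The estimated change is a 2.2-fold higher number from compound 3 to compound 4 (0.35 log units; beyond the scatter) as a move toward weaker inhibition. For compound 4 the estimated value is 3200 nM with an expected range of 900 nM to 10000 nM in this measurement.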

Compound 4, half-maximal inhibitory concentration: 9440 nM
For compound 4 the middle estimate is 3.0-fold (0.47 log units) below the measured one, and the stated range covers the measured number.
By their numbers in this assay, from the lowest: compound 3; then compound 2; then compound 4. At a limit, above all of these: compound 1.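

In this assay, compound 4 links compound 2 and compound 3, which differ in two places and so could not be compared directly. Tert-butoxycarbonyl on the amine nitrogen now has a step of its own, a 6.6-fold higher number from compound 3 to compound 4 (0.82 log units; beyond the scatter), and the isopropyl on the saturated chain carbon has another, a 2.2-fold higher number from compound 2 to compound 4 (0.34 log units; beyond the scatter); both run toward weaker inhibition, so replacing either group with hydrogen weakens inhibition in this pair. Compound 4 leaves little room under the top of the readable range, where compound 1 stands at a limit and not a number: the limit of > 10000 nM in this assay, at which 1 of the 4 values shown sits.

On these data alone, whether the gain on the amine nitrogen needs tert-butoxycarbonyl itself stays open, since an acetyl or a methyl group there would test this. Equally open, as far as these compounds go, is whether a methyl group on the saturated chain carbon would serve as well as isopropyl.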